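The source may report more compounds than this note shows. Statements on the series, on what has been measured and on what is new or still open speak of the compounds shown alone.

Measured compounds, solubility:

compound 1 `Cc1cc(NC(=O)Nc2ccc(C(=O)O)cc2)c2ccccc2n1`: 9300 nM
compound 2 `Cc1cc(NC(=O)Nc2ccccc2C(F)(F)F)c2ccccc2n1`: 3800 nM
compound 3 `Cc1cc(NC(=O)Nc2ccc(N)cc2)c2ccccc2n1`: 18500 nM

The series shares one core; in a physicochemical assay for solubility, at pH 7.4 (on this read-out lower numbers stand for lower solubility and higher numbers for higher solubility), compound 1 gives 9300 nM, the second highest of the three numbers. Its nearest neighbour is compound 3, and the change a 2.0-fold higher number from compound 1 to compound 3 (0.30 log units; within the scatter) keeps the two within the scatter of this assay, so no order can be read between them. Compound 2 sits further off, with a lower number that lies beyond the scatter of compound 1.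

The compound still to be measured is compound 4 `Cc1cc(NC(=O)Nc2ccc(O)cc2)c2ccccc2n1`. Against compound 1 the change is hydroxy in place of carboxy on an aromatic carbon. Going by the values given here, the only measured step that bears on this is the one on the same aromatic carbon, a 2.0-fold higher number from compound 1 to compound 3 (0.30 log units; within the scatter), which stayed within the scatter. Swapping the carboxy for a hydroxy is a change of the same kind at the same place, and the data hold no step that moved this read-out clearly when the carboxy was replaced. The expectation is therefore a step in this assay of no more than the scatter, in either direction, with a slight lean upward because compound 3 gave 18500 nM.

For compound 4 the estimated solubility is 11000 nM, with a range from 4500 nM to 26000 nM. The expected step is a 1.2-fold higher number from compound 1 to compound 4 (0.07 log units; within the scatter).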

Compound 4, solubility: 100 nM
The estimate for compound 4 lay 110-fold (2.04 log units) above the measured number, and the stated range ends above it.
By their numbers in this assay, from the lowest: compound 4; then compound 2; then compounds 1 and 3 (each within the scatter of the next).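

In this assay, going by these compounds alone, the group on this aromatic carbon, para to a large group, clearly matters: hydroxy in place of carboxy gives (a 93-fold lower number from compound 1 to compound 4 (1.97 log units; beyond the scatter)) and hydroxy in place of amino gives (a 190-fold lower number from compound 3 to compound 4 (2.27 log units; beyond the scatter)), both large, whereas the only earlier step at this carbon (a 2.0-fold higher number from compound 1 to compound 3 (0.30 log units; within the scatter)) stayed within the scatter. Carboxy and amino therefore do not mark out the range of this position, and the pair of compound 1 and compound 3 gave no sign of how far a single replacement here can move the number. Leaving carboxy and entering hydroxy carry the same counts of hydrogen-bond donors and acceptors, so those counts do not separate compound 1 from compound 4, and nothing at hand explains the fall.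

Open, as far as these compounds go, is whether the low number belongs to hydroxy alone or extends to related groups on the same carbon, such as methoxy, hydroxymethyl or a carboxamide. Also open, from the compounds shown here alone, is whether the replacement of carboxy by hydroxy keeps its size when an ethyl group or a longer chain stands in place of the methyl on the shared core.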